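A few compounds are considered here, and "the series" means these few. Any claim that something is new, unique, unknown or untested is made for them only; others in the source may bear on it.

Of the compounds shown here, two have been measured in a functional assay on DU-145 cells (Homo sapiens) for inhibition, read by trypan blue exclusion, with a stated time of 96 h; on this read-out higher numbers stand for weaker inhibition of growth and lower numbers for stronger inhibition of growth. Compound 1 (`Cc1ccc(CS/C(=C/c2ccccc2F)C(=O)c2ccc(Cl)cc2)cc1`) gives 10000 nM. Compound 2 (`Cc1ccc(S/C(=C/c2cc([N+](=O)[O-])ccc2F)C(=O)c2ccc(Cl)cc2)cc1`) gives 10000 nM, which places it level with compound 1, with no difference at the digits reported and nothing beyond the scatter of repeated measurements. Compound 3 (`Cc1ccc(CS/C(=C/c2cc([N+](=O)[O-])ccc2F)C(=O)c2ccc(Cl)cc2)cc1`) has not yet been measured in this assay. It differs from compound 2 in one place, on a sulfur whose other neighbour is a double-bonded chain carbon, where 4-methylbenzyl stands in place of 4-methylphenyl: 4-methylbenzyl in place of 4-methylphenyl on a sulfur. Within the data shown here, the data hold no measured step between compounds that differ in one place, so nothing shows directly how much this change matters. Starting from compound 2 at 10000 nM, only a small shift is expected, leaning towards stronger inhibition of growth and quite possibly no larger than the scatter. The expected change is a 1.7-fold lower number from compound 2 to compound 3 (0.22 log units; within the scatter). For compound 3 the estimated value is 6000 nM, with an expected range from 1500 nM to 15000 nM.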

Compound 3, concentration for 50% growth inhibition: 1000 nM
Estimate against measurement, compound 3: 6.0-fold (0.78 log units) above; measured number outside the range, below it.
By their numbers in this assay, from the lowest: compound 3; then compounds 1 and 2 (each within the scatter of the next).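

In this assay, among these compounds, these are the first steps between compounds that differ in one place, and they show that the group on this sulfur affects the result: 4-methylbenzyl in place of 4-methylphenyl gives (a 10-fold lower number from compound 2 to compound 3 (1.00 log units; beyond the scatter)), a step beyond the scatter. The nitro group also counts, since nitro in place of hydrogen on an aromatic carbon, with 4-methylbenzyl kept on the sulfur, gives (a 10-fold lower number from compound 1 to compound 3 (1.00 log units; beyond the scatter)), which is likewise beyond the scatter. Compound 3 carries both groups, and losing either one alone takes the number back up, but nothing available explains why either change has this effect.

Going by these compounds, both steps end at compound 3, so it remains open whether the two changes act independently or only together, a question that a compound with 4-methylphenyl on the sulfur and hydrogen in place of the nitro would address. On these data alone, it is also open whether a longer chain such as 2-phenylethyl on the sulfur would continue the trend, and whether an amine or a nitrile in place of the nitro would keep the lower number.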